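The compounds below may be only part of what the source reports. "The series", "measured", "known", "first", "only" and "open" are said of these compounds alone.

Measured compounds:
compound 1, `[O-][n+]1nc(NCc2ccccc2Cl)[n+]([O-])c2ccccc21`, 10600 nM
compound 2, `[O-][n+]1nc(NCCO)[n+]([O-])c2ccccc21`, 22400 nM
compound 3, `CCCCCCCCNc1n[n+]([O-])c2ccccc2[n+]1[O-]`, 18200 nM

In a functional assay on PC-3 cells (Homo sapiens) for cytotoxicity, read by MTT assay, with a stated time of 48 h (a higher number here means a weaker inhibitor, a lower number a stronger inhibitor), compound 2 gives the highest of the three numbers. Its step of a 2.1-fold higher number from compound 1 to compound 2 (0.32 log units; beyond the scatter) is the only one of the three that reaches beyond the scatter, while a 1.2-fold lower number from compound 2 to compound 3 (0.09 log units; within the scatter) and a 1.7-fold higher number from compound 1 to compound 3 (0.23 log units; within the scatter) both stay within it, so compound 2 and compound 3 cannot be told apart on these numbers.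

Compound 4, `CCN(CC)c1n[n+]([O-])c2ccccc2[n+]1[O-]`, differs from compound 2 by diethylamino in place of (2-hydroxyethyl)amino on an aromatic carbon. Within the data shown here, no measured step makes this same exchange. The nearest is a 1.2-fold lower number from compound 2 to compound 3 (0.09 log units; within the scatter), where the hydroxy group was exchanged for a hexyl chain without a shift beyond the scatter, which suggests that removing the hydroxy group by itself does little here. Among the measured compounds shown here, the loss of the amine hydrogen in compound 4, however, has no counterpart among the measured compounds, and all three measured compounds keep that hydrogen. For the measured compounds named here, the expected step in this assay is therefore a 1.1-fold lower number from compound 2 to compound 4 (0.05 log units; within the scatter), that is, no change beyond the scatter, with wider uncertainty than the single nearby step alone would imply. Compound 4 is estimated at 20000 nM in this assay, with a range from 7000 nM to 55000 nM.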

Compound 4, half-maximal inhibitory concentration: > 107000 nM
Compound 4 gave a limit, no number (the forecaster's own chance of this, stated with the estimate: 10%); middle value at least 5.3-fold (0.72 log units) from the limit.
By their numbers in this assay, from the lowest: compounds 1, 3 and 2 (each within the scatter of the next, the first and the last beyond it). At a limit, above all of these: compound 4.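

In this assay, compound 4 gives > 107000 nM, which is a limit of the assay and not a number: the limit of > 107000 nM in this assay, at which 1 of the 4 values shown sits. Among the earlier compounds, changing the group on the amine nitrogen shifted the number by no more than a 2.1-fold higher number from compound 1 to compound 2 (0.32 log units; beyond the scatter), so this position seemed to tolerate quite different chains as long as the amine hydrogen stayed. Among these compounds, the exchange of (2-hydroxyethyl)amino for diethylamino on the aromatic carbon between two ring nitrogen atoms gives an at least 4.7-fold higher number from compound 2 to compound 4 (0.67 log units; beyond the scatter), which shows that this position is not indifferent to every change and that the first group here without the amine hydrogen is also the one with the clearest loss.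

The single exchange removes the hydroxy group and the amine hydrogen and adds a second ethyl group all at once, and the compounds shown do not separate these changes, though an ethylamino group, which keeps the amine hydrogen, would bear on this directly. Going by these compounds, whether a smaller dimethylamino group or a ring amine such as morpholine would behave like diethylamino also remains open, as does the true size of the step.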